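A few compounds are considered here, and "the series" means these few. Any claim that something is new, unique, unknown or untested is made for them only; others in the source may bear on it.

In an assay on isolated protein for inhibition of serine/threonine-protein kinase PAK 1 (Homo sapiens), read by ADP-Glo, with a stated time of 40 min (a lower number here means a stronger inhibitor, a higher number a weaker inhibitor), compound 1 `O=C(NC1CCN(c2ncnc3[nH]ncc23)CC1)c1ccc(F)cc1` gives 4540 nM, compound 2 `O=C(NC1CCN(c2ncnc3[nH]ncc23)CC1)c1ccc(Br)cc1` gives 16400 nM, and compound 3 `O=C(Nc1ccccc1Cl)NC1CCN(c2ncnc3[nH]ncc23)CC1` gives 560 nM. Compound 3 thus has the lowest number of the three, well beyond the scatter from either of the others. Compound 4 `O=C(Nc1ccc(F)cc1F)NC1CCN(c2ncnc3[nH]ncc23)CC1` differs from compound 3 in one place: 2,4-difluorophenyl in place of 2-chlorophenyl on an amide-type nitrogen. The closest measured guide is the halogen swap a 3.6-fold higher number from compound 1 to compound 2 (0.56 log units; beyond the scatter), a modest change on a different arm. The larger steps of an 8.1-fold lower number from compound 1 to compound 3 (0.91 log units; beyond the scatter) and a 29-fold lower number from compound 2 to compound 3 (1.47 log units; beyond the scatter) concern the whole arm and bear only loosely. A small step is therefore expected, a 1.4-fold higher number from compound 3 to compound 4 (0.15 log units; within the scatter), in no firm direction. Compound 4 is expected to give 800 nM, within about 250 nM to 2500 nM.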

Compound 4, half-maximal inhibitory concentration: 1140 nM
Beside the measured number, compound 4's estimate is 1.4-fold (0.15 log units) below it, and the stated range covers the measured number.
By their numbers in this assay, from the lowest: compound 3; then compound 4; then compound 1; then compound 2.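

The step of a 2.0-fold higher number from compound 3 to compound 4 (0.31 log units; beyond the scatter) shows that the aryl group on this amide-type nitrogen matters: 2,4-difluorophenyl gives back part of what 2-chlorophenyl gained. Still, a 4.0-fold lower number from compound 1 to compound 4 (0.60 log units; beyond the scatter) and a 14-fold lower number from compound 2 to compound 4 (1.16 log units; beyond the scatter) show that a second arm of this amino type also sits lower than both compounds with an aryl group directly on the carbonyl carbon. No evidence on the cause of these steps is at hand.

As far as these compounds go, whether plain phenyl, 2-fluorophenyl or a cyclohexyl ring on this nitrogen would lower the number further stays open. So does the separate contribution of each fluorine.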